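Fluorine position on the terminal aryl urea

This account rests on a few compounds, and the source may have more. Where it says the series, first, only, none or still open, it means among the compounds named here.

Compound 1 `COc1cc(NC(=O)Nc2cccc(F)c2)cc(OC)c1OC` is the reference point of this small set. In a functional assay on ONS-76 cells (Homo sapiens) for cytotoxicity, read by MTT assay, with a stated time of 72 h (a lower number here means a stronger inhibitor, a higher number a weaker inhibitor), compound 1 gives 65600 nM, the only plain number shown for the series. Compound 2 `COc1cc(NC(=O)Nc2ccc3c(ccn3C)c2)cc(OC)c1OC` returns a limit of the assay in this assay: >= 125000 nM. Compound 3 `COc1cc(N(C)C(=O)N(C)c2ccccc2)cc(OC)c1OC` has no result reported in this assay ("not determined" (no result reported)). One observation stands out: the limit of >= 125000 nM in this assay, at which 1 of the 3 values shown sits. Among the compounds with values here, no step between two measured compounds that differ in a single place can be read from these three, so no step size is anchored by data.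

Compound 4 `COc1cc(NC(=O)Nc2ccc(F)cc2)cc(OC)c1OC` differs from compound 1 only by 4-fluorophenyl in place of 3-fluorophenyl on an amide-type nitrogen. Within the data shown here, the two aryl groups carry the same atoms, and the series holds no measured step of this kind, so no change beyond the scatter is expected; the expected step from compound 1 to compound 4 is a 1.1-fold lower number from compound 1 to compound 4 (0.04 log units; within the scatter). The estimate for compound 4 in this assay is 60000 nM, within a range from 25000 nM to 150000 nM. Compound 2 shows a limit >= 125000 nM in this assay, and a reported limit rather than a number remains possible for compound 4 as well.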

Compound 4, half-maximal inhibitory concentration: 63300 nM
Beside the measured number, compound 4's estimate is 1.1-fold (0.02 log units) below it, within the range that was stated.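

Within the data shown here, with the fluorine moved on the terminal aryl, this assay gives a 1.0-fold lower number from compound 1 to compound 4 (0.02 log units; within the scatter), the first step that can be read. Compound 1 alone could not show how this place responds to a change, and the step now shows that 4-fluorophenyl in place of 3-fluorophenyl on an amide-type nitrogen makes no difference beyond the scatter, so the two fluorine placements are not separated by this read-out. Nothing measured in the series accounts for this result.

From the compounds shown here alone, the response of this aryl group to anything other than a shifted fluorine stays open, for instance a carboxylic acid or a dimethylamino group in place of the fluorine, since both fluorophenyl compounds test only one substituent in two placements. Among these compounds, compound 2 gives >= 125000 nM, a limit of the assay and not a number, so it offers no step to set against the one from the fluorine shift.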